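Compound 3 and a longer ester in the formyl's place

The source may report more compounds than this note shows. Statements on the series, on what has been measured and on what is new or still open speak of the compounds shown alone.

Compound 1 `C=C[C@@](C)(/C=C/c1ccc(O)cc1)CCC=O` gives > 36600 nM as a limit of the assay, not a number
Compound 2 `C=C[C@@](C)(/C=C/c1ccc(O)c(/C=C/C(=O)c2ccccc2)c1)CCC=C(C)C` gives > 7410 nM as a limit of the assay, not a number
Compound 3 `COc1ccc(/C=C/[C@@](C)(/C=C/c2ccc(O)c(C=O)c2)CCC=C(C)C)cc1` gives 2270 nM as a true number

Among the compounds with values here, in an ADME assay on HEK293 cells (Homo sapiens) for cytotoxicity, with a stated time of 72 h (on this read-out higher numbers stand for an effect only at larger amounts of compound and lower numbers for an effect already at smaller amounts), compound 3 gives 2270 nM as the only true number of the three, so it is the single firm reference point here. The other two compounds report only limits.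

Compound 4 `CCOC(=O)/C=C/c1cc(/C=C/[C@](C)(/C=C/c2ccc(OC)cc2)CCC=C(C)C)ccc1O` differs from compound 3 in one place, with 2-(ethoxycarbonyl)ethenyl in place of formyl on an aromatic carbon, ortho to a hydroxy group 2-(ethoxycarbonyl)ethenyl in place of formyl on an aromatic carbon and meta to a large group.

Within the data shown here, no measured pair shows what such a change does in this assay, so any forecast is uncertain. A small move towards a higher number is expected, and the expected size is a 1.5-fold higher number from compound 3 to compound 4 (0.19 log units; within the scatter) at most modestly beyond the usual scatter. Compound 4 might also return only a limit. Compound 4 is estimated at 3500 nM with an expected range of 1200 nM to 10000 nM overall.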

Compound 4, half-maximal effective concentration: > 36600 nM
Compound 4 was reported as a limit (the forecaster's own chance of this, stated with the estimate: 30%); at least 10-fold (1.01 log units) between middle value and limit.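

In this assay, the place on an aromatic carbon, ortho to a hydroxy group, proves sensitive: putting 2-(ethoxycarbonyl)ethenyl there in place of formyl gives an at least 16-fold higher number from compound 3 to compound 4 (1.20 log units; beyond the scatter). The earlier compounds shown here formed no pair differing in one place, so they could not tie any change in this read-out to a single group. The result for compound 4 is a limit of the assay, not a number, so the full size of the step remains unknown: the limit of > 36600 nM in this assay, at which 2 of the 4 values shown sit.

The compounds shown do not reveal which part of 2-(ethoxycarbonyl)ethenyl goes with the change: its ethyl ester, its double bond or its greater size. A carboxylic acid or an amide in place of the ethyl ester, or a saturated chain in place of the ethenyl link, would help separate these parts.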